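The source may hold more compounds than are shown below. What is called first, only, known or untested is meant among the compounds shown, and "the series" means these compounds.

In a functional assay on NCI-H460 cells (Homo sapiens) for inhibition, read by MTT assay, with a stated time of 24 h, tested at 10 ug/mL (on this read-out higher numbers stand for more inhibition of growth at the one concentration tested and lower numbers for less inhibition of growth), compound 1 `O=C(O)CCCCC(CCSC(=O)c1ccccc1)SC(=O)c1ccccc1` is reported as "not active" (no number reported) and so stands without a number. Going by the values given here, compound 2 `O=C(CCCCC1CCSS1)Nc1ccc(OC(F)(F)F)cc1` gives 20.3% and holds the only number so far. Compound 3 `O=C(CCCCC(CCSC(=O)c1ccccc1)SC(=O)c1ccccc1)Nc1ccc(Cl)cc1` keeps the core of compound 1 with one change, (4-chlorophenyl)amino in place of hydroxy on a carbonyl carbon in all, which puts (4-chlorophenyl)amino in place of hydroxy on a carbonyl carbon. In this assay, among the compounds with values here, no measured step shows what this change does, so only a modest rise in inhibition is expected, toward the level of compound 2 at 20.3% and not clearly past it. For compound 3 the estimate is 20% with an expected range from 5% to 45% on this measure.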

Compound 3, percent growth inhibition at one concentration: 12.6%
For compound 3 the middle estimate is 7.4 percentage points above the measured one; measured number inside the range.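

Going by these compounds alone, compound 1 has no number in this assay so no step from it to compound 3 can be read. The compounds shown leave open how far (4-chlorophenyl)amino in place of hydroxy changes growth inhibition, and nothing here bears on a cause.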